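Replacing the Dichlorophenyl Group on a Hydrazone Urea

The source may report more compounds than this note shows. Statements on the series, on what has been measured and on what is new or still open speak of the compounds shown alone.

Compound 1 `CN(C)CCn1cnnc1-c1cc(Oc2ccc(NC(=O)N/N=C/c3c(Cl)cccc3Cl)cc2F)ccn1`: > 100000 nM
Compound 2 `CN(C)CCn1cnnc1-c1cc(Oc2ccc(NC(=O)N/N=C/c3ccccc3O[N+](=O)[O-])cc2F)ccn1`: 7150 nM
Compound 3 `CN(C)CCn1cnnc1-c1cc(Oc2ccc(NC(=O)N/N=C/c3ccccc3)cc2F)ccn1`: 2250 nM

These three compounds share one core and differ only in the aryl group on the carbon double-bonded to nitrogen. In a functional assay on U-87MG ATCC cells (Homo sapiens) for cytotoxicity, read by MTT assay, with a stated time of 72 h (on this read-out higher numbers stand for weaker inhibition and lower numbers for stronger inhibition), compound 1 gives > 100000 nM, which is a limit of the assay and not a number. Compound 2 gives 7150 nM, and compound 3 gives 2250 nM. Compound 4 `CN(C)CCn1cnnc1-c1cc(Oc2ccc(NC(=O)N/N=C/c3cc(Br)c(O)c(Br)c3)cc2F)ccn1` is not yet measured. It differs from compound 1 thus: 3,5-dibromo-4-hydroxyphenyl in place of 2,6-dichlorophenyl on a carbon with a double bond to nitrogen. Among the measured compounds shown here, two measured steps bear on this change, both replacing the same 2,6-dichlorophenyl: an at least 13-fold lower number from compound 1 to compound 2 (1.14 log units; beyond the scatter) and an at least 44-fold lower number from compound 1 to compound 3 (1.64 log units; beyond the scatter). Because compound 1 sits at the limit of > 100000 nM in this assay, at which 1 of the 3 values shown sits, its step to compound 4 is expected to be large and downward as well, an at least 20-fold lower number from compound 1 to compound 4 (1.30 log units; beyond the scatter). Compound 4 is therefore estimated at 5000 nM, within 1500 nM to 30000 nM.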

Compound 4, half-maximal inhibitory concentration: > 100000 nM
Compound 4 gave a limit, no number (the forecaster's own chance of this, stated with the estimate: 15%); middle value at least 20-fold (1.30 log units) from the limit.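

A change at this carbon does not always lower the number: with 3,5-dibromo-4-hydroxyphenyl in place, this assay shows an at least 44-fold higher number from compound 3 to compound 4 (1.64 log units; beyond the scatter) and an at least 13-fold higher number from compound 2 to compound 4 (1.14 log units; beyond the scatter). The two compounds with two halogen atoms on this ring, compound 1 and compound 4, now share a limit of the assay rather than a number: the limit of > 100000 nM in this assay, at which 2 of the 4 values shown sit. The step between these two limits cannot be read.

The compounds shown do not separate the effect of the two bromine atoms from that of the hydroxyl group. They also leave open how an aryl group carrying an amine or a carboxylic acid would behave here.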